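The source may report more compounds than this note shows. Statements on the series, on what has been measured and on what is new or still open speak of the compounds shown alone.

Compound 1 `O=C(C1=C(OC2CCCCC2)C(=O)N(CCCn2ccnc2)C1c1ccc(Br)cc1)c1ccccc1` gives 19900 nM in a functional assay on NCI-H1299 cells (Homo sapiens) for antiproliferative activity, read by MTT assay, with a stated time of 72 h; a lower number here means a stronger inhibitor, a higher number a weaker inhibitor.
Compound 2 `O=C(C1=C(Nc2ccc(Br)cc2)C(=O)N(CCCn2ccnc2)C1c1ccc(Br)cc1)c1ccccc1` gives 19300 nM.
Compound 3 `O=C(C1=C(Nc2cccc(Br)c2)C(=O)N(CCCn2ccnc2)C1c1ccc(Br)cc1)c1ccccc1` gives 11500 nM.

Among these three, compound 1 carries the highest of the numbers, but the steps to the other two are both within the scatter: a 1.0-fold lower number from compound 1 to compound 2 (0.01 log units; within the scatter) and a 1.7-fold lower number from compound 1 to compound 3 (0.24 log units; within the scatter). The pair of arylamino compounds are likewise close to each other, a 1.7-fold lower number from compound 2 to compound 3 (0.22 log units; within the scatter).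

Compound 4 `O=C(C1=C(NCc2ccccc2)C(=O)N(CCCn2ccnc2)C1c1ccc(Br)cc1)c1ccccc1` is reached from compound 1 by one change: benzylamino in place of cyclohexyloxy on a double-bonded ring carbon. The two measured steps that bear on this are those from compound 1 to compound 2 and from compound 1 to compound 3, where the cyclohexyloxy group was also exchanged for a nitrogen-linked substituent at the same double-bonded ring carbon, and neither moved the number beyond the scatter. A benzylamino group has not been tested at this position, but on the evidence of those two replacements, little movement is expected. Compound 4 is therefore estimated at 15000 nM with a range of 6000 nM to 40000 nM, a step of a 1.3-fold lower number from compound 1 to compound 4 (0.12 log units; within the scatter) that is expected to stay within the scatter.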

Compound 4, half-maximal inhibitory concentration: 25300 nM
Estimate against measurement, compound 4: 1.7-fold (0.23 log units) below; low and high end bracket the measured number.
By their numbers in this assay, from the lowest: compounds 3, 2, 1 and 4 (each within the scatter of the next, the first and the last beyond it).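

Benzylamino is a third nitrogen-linked group at this double-bonded ring carbon, and with a 1.3-fold higher number from compound 1 to compound 4 (0.10 log units; within the scatter) in this assay it also stays level with cyclohexyloxy. Among these compounds, on the amine nitrogen, the step of a 1.3-fold higher number from compound 2 to compound 4 (0.12 log units; within the scatter) shows benzyl level with 4-bromophenyl, whereas a 2.2-fold higher number from compound 3 to compound 4 (0.34 log units; beyond the scatter) is the first step in this set to pass the scatter, though only modestly, so the position of the bromine on the aryl ring separates the two aryl compounds from benzyl differently. Nothing available bears on why this modest step arises.

On these data alone, it remains open whether a phenethylamino group with its longer chain, or a piperidine or carboxylic acid at this carbon, would move the number further. Also open, as far as these compounds go, is whether a 3-chlorophenyl group on the amine nitrogen would behave like 3-bromophenyl.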